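A few compounds are considered here, and "the series" means these few. Any claim that something is new, unique, unknown or untested is made for them only; others in the source may bear on it.

Compound 1, `O=C(N/N=C/c1cccc([N+](=O)[O-])c1)c1cccc([N+](=O)[O-])c1`, gives 3.33 in a physicochemical assay for lipophilicity; on this read-out lower numbers stand for lower lipophilicity and higher numbers for higher lipophilicity.
Compound 2, `O=C(N/N=C/c1cccc([N+](=O)[O-])c1)c1cc([N+](=O)[O-])ccc1Cl`, gives 3.85 in this assay.
Compound 3, `COc1ccc(/C=N/NC(=O)c2cccc([N+](=O)[O-])c2)cc1OC`, gives 2.87 in this assay.

Compound 4, `COc1ccc(/C=N/NC(=O)c2cc([N+](=O)[O-])ccc2Cl)cc1OC`, has not yet been measured. It arises from compound 3 by chloro in place of hydrogen on an aromatic carbon. The same change has been made once before, from compound 1 to compound 2, where it is chloro in place of hydrogen on an aromatic carbon, and in this assay it gave a number 0.52 log units higher from compound 1 to compound 2 (beyond the scatter). Both changes sit in the same kind of place, so this is the same change made on a different core. How the core of compound 3 differs from the core of compound 1 is not broken down here. Compound 3 stands lowest of the three measured compounds in this assay. Because the earlier step was a number 0.52 log units higher from compound 1 to compound 2 (beyond the scatter), a step of similar size is expected here, namely a number 0.52 log units higher from compound 3 to compound 4 (beyond the scatter). The estimated value for compound 4 is 3.39, with a likely range from 3.05 to 3.75.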

Compound 4, partition coefficient: 3.39
For compound 4 middle estimate and measured number coincide at the digits printed, and the stated range covers the measured number.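

In this assay, chloro in place of hydrogen on an aromatic carbon gives a number 0.52 log units higher from compound 3 to compound 4 (beyond the scatter), and on the earlier core the same change gave a number 0.52 log units higher from compound 1 to compound 2 (beyond the scatter), so the step carried across these two cores with no difference at the digits printed. For the compounds shown here, this is only one pair of cores with the chloro in one place, so it does not show that the step would hold on every core or at another place on the ring. No measurement here speaks to the reason for the match.

As far as these compounds go, it remains open whether another group in that place, such as fluoro, methyl or an amine, would give a step of similar size. From the compounds shown here alone, it is also open whether the chloro step would stay the same on a core carrying a carboxylic acid or a longer chain.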